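This account rests on a few compounds, and the source may have more. Where it says the series, first, only, none or still open, it means among the compounds named here.

Measured compounds:
- compound 1, `COCc1nc(Nc2ccc(C(F)(F)F)cc2)c2ccc(-c3ncccc3C(F)(F)F)cc2n1`: 1.5 nM in a functional assay for antagonist activity at transient receptor potential cation channel subfamily V member 1 (Homo sapiens); on this read-out higher numbers stand for weaker inhibition and lower numbers for stronger inhibition
- compound 2, `CCOCc1nc(Nc2ccc(C(F)(F)F)cc2)c2ccc(-c3ncccc3C(F)(F)F)cc2n1`: 0.9 nM in this assay
- compound 3, `OCCCc1nc(Nc2ccc(C(F)(F)F)cc2)c2ccc(-c3ncccc3C(F)(F)F)cc2n1`: 25 nM in this assay

Compound 3 gives the highest of the three numbers in this assay; the step of a 17-fold higher number from compound 1 to compound 3 (1.22 log units; beyond the scatter) and the step of a 28-fold higher number from compound 2 to compound 3 (1.44 log units; beyond the scatter) both lie well beyond the scatter, while a 1.7-fold lower number from compound 1 to compound 2 (0.22 log units; within the scatter) does not. Both large steps replace an alkoxy group at the chain terminus with a 2-hydroxyethyl group, so within this small set the chain carrying a hydroxyl is the weakest-inhibiting variant.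

Compound 4, `CS(=O)(=O)CCc1nc(Nc2ccc(C(F)(F)F)cc2)c2ccc(-c3ncccc3C(F)(F)F)cc2n1`, is not yet measured. It differs from compound 3 by methylsulfonyl in place of hydroxymethyl on a saturated chain carbon, two bonds along the chain from an aromatic carbon. Going by the values given here, no measured pair shows this exact exchange. Among the compounds with values here, what can be said is that compound 1 and compound 2, each carrying an oxygen on the chain but no hydrogen-bond donor, give the lower numbers, and compound 3, the only compound with a donor, gives the higher one. Within the data shown here, compound 4 again has no donor, so a step downward from compound 3 is expected, a 3.1-fold lower number from compound 3 to compound 4 (0.49 log units; beyond the scatter), though the methylsulfonyl group has no direct precedent here and the size of the step is uncertain. Compound 4 is therefore expected at 8 nM, range 2 nM to 40 nM.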

Compound 4, half-maximal inhibitory concentration: 36 nM
Estimate against measurement, compound 4: 4.5-fold (0.65 log units) below; low and high end bracket the measured number.
By their numbers in this assay, from the lowest: compounds 2 and 1 (each within the scatter of the next); then compounds 3 and 4 (each within the scatter of the next).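

In this assay, methylsulfonyl in place of hydroxymethyl, on a saturated chain carbon two bonds along the chain from an aromatic carbon, gives a 1.4-fold higher number from compound 3 to compound 4 (0.16 log units; within the scatter) and so leaves compound 3 and compound 4 indistinguishable. Compound 4 has no hydrogen-bond donor, yet a 40-fold higher number from compound 2 to compound 4 (1.60 log units; beyond the scatter) and a 24-fold higher number from compound 1 to compound 4 (1.38 log units; beyond the scatter) are both large steps, so compound 4 goes against the earlier link between a donor on the chain and a higher number, and losing the donor alone does not restore the low numbers of the alkoxy compounds. Nothing at hand explains this result.

In the large steps, the chain length and the end group change together, so their contributions cannot be separated. As far as these compounds go, a 2-methoxyethyl chain, or an amine or carboxylic acid at this place, remains open.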